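The source may hold more compounds than are shown below. What is called first, only, known or untested is meant among the compounds shown, and "the series" means these compounds.

Measured in an ADME assay on a cell-free system (plasma, Sus scrofa) for metabolic stability, read by LC-MS, with a stated time of 1 h, tested at 10 uM; on this read-out lower numbers stand for a less stable compound and higher numbers for a more stable compound:
- compound 1 `CCCCCCCCCCCCCCCC(=O)N[C@@H](CCCCNC(C)=O)C(=O)N[C@@H](CCC(=O)C=[N+]=[N-])C(=O)OC(C)C`: 88%
- compound 2 `CC(=O)NCCCC[C@H](NC(=O)OC(C)(C)C)C(=O)N[C@@H](CCC(=O)C=[N+]=[N-])C(=O)OC(C)C`: 85%

Compound 1 at 88% and compound 2 at 85% lie within the usual scatter of each other, so neither stands apart on these numbers. The next molecule, compound 3 `CCCCCCCC(=O)N[C@@H](CCCCNC(C)=O)C(=O)N[C@@H](CCC(=O)C=[N+]=[N-])C(=O)OC(C)C`, keeps the core of compound 1 and changes only the fatty chain: hydrogen in place of octyl on a saturated chain carbon, seven bonds along the chain from a carbonyl carbon. In words, hydrogen takes the place of octyl on a saturated chain carbon, seven bonds along the chain from a carbonyl carbon. Going by the values given here, no measured pair shows what this change does, so the expectation rests only on the two close values. In this assay, no shift beyond the scatter is expected, and the estimated change is a number 4 percentage points lower from compound 1 to compound 3 (within the scatter). Compound 3 is expected at 84%, with an estimated range from 68% to 97%.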

Compound 3, percent of the compound remaining: 91%
Beside the measured number, compound 3's estimate is 7 percentage points below it, and the stated range covers the measured number.
By their numbers in this assay, from the lowest: compounds 2, 1 and 3 (each within the scatter of the next).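

In this assay, going by these compounds alone, the first measured pair at this position gives a number 3 percentage points higher from compound 1 to compound 3 (within the scatter) when hydrogen replaces octyl on a saturated chain carbon, seven bonds along the chain from a carbonyl carbon, so removing this much of the fatty chain leaves the two compounds indistinguishable here. Replacing tert-butoxy with heptyl on a carbonyl carbon gives a number 6 percentage points higher from compound 2 to compound 3 (within the scatter) and likewise does not separate the two compounds. No independent information is available to explain these results.

On these data alone, it remains open whether an amine or a carboxylic acid on that saturated chain carbon, or a longer chain, would also stay this close to compound 1. With all three compounds within the scatter of the next, the data do not show which part of the structure, if any, controls the read-out in this assay.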